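Cytotoxicity notes on sulfonylation of the ring amine

The source may report more compounds than this note shows. Statements on the series, on what has been measured and on what is new or still open speak of the compounds shown alone.

In an ADME assay on L02 cells (Homo sapiens) for cytotoxicity, read by MTT assay, with a stated time of 24 h (a lower number here means a stronger inhibitor, a higher number a weaker inhibitor), compound 1 `CN1C/C(=C\c2ccc(C#N)cc2)C(=O)/C(=C/c2cccnc2)C1` gives > 20000 nM, which is a limit and not a number. Compound 2 `COc1cc(/C=C2\CN(C)C/C(=C\c3ccncc3)C2=O)cc(OC)c1OC` gives 16400 nM and compound 3 `O=C1/C(=C/c2cccnc2)CNC/C1=C\c1ccccc1F` gives 15900 nM, so these two stand level, within the scatter of each other. Compound 4 `N#Cc1ccc(S(=O)(=O)N2C/C(=C\c3cccnc3)C(=O)/C(=C/c3ccccc3F)C2)cc1` derives from compound 3 through ((4-cyanophenyl)sulfonyl in place of hydrogen on an amine nitrogen in a ring), with (4-cyanophenyl)sulfonyl in place of hydrogen on an amine nitrogen in a ring. Within the data shown here, no measured pair isolates a change at this nitrogen, so only a modest step towards a lower number is expected in this assay, starting from compound 3 at 15900 nM. The expected step is a 1.3-fold lower number from compound 3 to compound 4 (0.12 log units; within the scatter). For compound 4 the estimate is 12000 nM, with an expected range of 5000 nM to 25000 nM.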

Compound 4, half-maximal inhibitory concentration: > 20000 nM
Compound 4 gave a limit, no number (the forecaster's own chance of this, stated with the estimate: 35%); middle value at least 1.6-fold (0.22 log units) away from the limit.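

In this assay, among these compounds, (4-cyanophenyl)sulfonyl in place of hydrogen on an amine nitrogen in a ring gives the first readable change at this nitrogen, and no lower number appears: an at least 1.2-fold higher number from compound 3 to compound 4 (0.09 log units; that floor lies within the scatter). Compound 4 gives > 20000 nM, which is a limit and not a number. As far as these compounds go, the true size of the step stays unknown, because the read-out ends at that limit: the limit of > 20000 nM in this assay, at which 2 of the 4 values shown sit.

Still open, from the compounds shown here alone, is how an acetyl or a benzyl group on this nitrogen would read, and whether any such group would give a number short of the limit.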